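Cyclohexyl for chlorophenyl on the cyclopropane of compound 3

The source may hold more compounds than are shown below. What is called first, only, known or untested is meant among the compounds shown, and "the series" means these compounds.

Compound 1, `CC(C)CCCN(C(=O)[C@@H]1C[C@H]1c1ccccc1)c1ccc(-c2ccccc2)cc1`: > 100 nM in a functional assay for agonist activity at G protein-coupled receptor 88 (Homo sapiens), read by HTRF and cAMP accumulation; a lower number here means that less compound is needed, a higher number that more compound is needed for the effect
Compound 2, `CC(C)C[C@@H](N)CN(C(=O)[C@@H]1C[C@H]1c1ccccc1)c1ccc(-c2ccccc2)cc1`: 1.8 nM
Compound 3, `CC[C@H](C)[C@H](N)CN(C(=O)[C@@H]1C[C@H]1c1ccccc1Cl)c1ccc(-c2ccccc2)cc1`: > 25000 nM

For compound 3 the value in this assay is only a limit, (the limit of > 25000 nM in this assay, at which 1 of the 3 values shown sits); no number is known for it. Compound 1 likewise gives only a limit, (the limit of > 100 nM in this assay, at which 1 of the 3 values shown sits), and among the three measured compounds only compound 2 has a proper number. For the measured compounds named here, the one measured step is an at least 55-fold lower number from compound 1 to compound 2 (1.74 log units; beyond the scatter), and it concerns the amino group, not the ring on the cyclopropane; no measured pair shows what happens when the aryl ring is exchanged.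

Compound 4, `CC[C@H](C)[C@H](N)CN(C(=O)[C@@H]1C[C@H]1C1CCCCC1)c1ccc(-c2ccccc2)cc1`, is yet to be measured. It differs from compound 3 in one place: cyclohexyl in place of 2-chlorophenyl on a saturated ring carbon. Going by the values given here, since compound 3 stands at a limit and no measured step bears on this change, the size of the step that the limit leaves unreadable from compound 3 to compound 4 is expected to be small, and it is expected that compound 4 most likely also gives only a limit. As a number, compound 4 is expected at 30000 nM, within a range of 3000 nM to 150000 nM.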

Compound 4, half-maximal effective concentration: > 25000 nM
Compound 4: no number, only a limit (the forecaster's own chance of this, stated with the estimate: 65%); the middle value is on the limit's open side.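

In this assay compound 4 gives > 25000 nM, which is a limit and not a number. Compound 3 gives > 25000 nM, also a limit, so no step can be read between compound 3 and compound 4. What the compounds shown leave open is whether cyclohexyl in place of 2-chlorophenyl changes the value at all.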